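From Sulfone to Thioether in a Weakly Cytotoxic Series

The source may hold more compounds than are shown below. What is called first, only, known or untested is meant among the compounds shown, and "the series" means these compounds.

Within the data shown here, the three compounds measured so far share one core and differ only in a halogen: compound 1 `CC(O)(CS(=O)(=O)c1ccc(Br)cc1)c1nc(-c2ccc([N+](=O)[O-])c(C(F)(F)F)c2)no1`, compound 2 `CC(O)(CS(=O)(=O)c1ccc(Cl)cc1)c1nc(-c2ccc([N+](=O)[O-])c(C(F)(F)F)c2)no1` and compound 3 `CC(O)(CS(=O)(=O)c1ccc(F)cc1)c1nc(-c2ccc([N+](=O)[O-])c(C(F)(F)F)c2)no1`. In a functional assay on DU-145 cells (Homo sapiens) for cytotoxicity, read by MTT assay (on this read-out higher numbers stand for weaker inhibition and lower numbers for stronger inhibition), compound 3 gives only a limit of the assay, > 100000 nM. Compound 1 likewise gives a limit, > 100000 nM. Compound 2 gives 91000 nM. Given (the limit of > 100000 nM in this assay, at which 2 of the 3 values shown sit), the steps of an at least 1.0-fold lower number from compound 1 to compound 2 (0.04 log units; that floor lies within the scatter) and an at least 1.0-fold higher number from compound 2 to compound 3 (0.04 log units; that floor lies within the scatter) stay within the scatter, and a step that the two limits leave unreadable from compound 1 to compound 3 cannot be read. Compound 4 `CC(O)(CSc1ccc(F)cc1)c1nc(-c2ccc([N+](=O)[O-])c(C(F)(F)F)c2)no1` carries (4-fluorophenyl)sulfanyl in place of (4-fluorophenyl)sulfonyl on a saturated chain carbon, two bonds along the chain from an aromatic carbon and an oxygen on a saturated carbon. Among the measured compounds shown here, no measured step touches this part of the molecule, so no step beyond the scatter is expected in this assay: a number no higher from compound 3 to compound 4 (the limit leaves the size open). Compound 4 is therefore estimated at 100000 nM, between 30000 nM and 300000 nM.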

Compound 4, half-maximal inhibitory concentration: 5100 nM
The estimate for compound 4 lay 20-fold (1.29 log units) above the measured number; the measured number lies below the stated range.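

In this assay, the sulfur link at this saturated chain carbon matters in a way the halogen did not: (4-fluorophenyl)sulfanyl in place of (4-fluorophenyl)sulfonyl gives an at least 19-fold lower number from compound 3 to compound 4 (1.29 log units; beyond the scatter). The steps from the other two sulfones agree, with an 18-fold lower number from compound 2 to compound 4 (1.25 log units; beyond the scatter) and an at least 19-fold lower number from compound 1 to compound 4 (1.29 log units; beyond the scatter), whereas the halogen steps stayed within the scatter or could not be read. Two of these three sizes are floors only: the limit of > 100000 nM in this assay, at which 2 of the 4 values shown sit.

The compounds shown leave open where a sulfinyl link would fall. They also leave open whether chloro or bromo in place of fluoro on the sulfanyl ring would change the number.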